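This account rests on a few compounds, and the source may have more. Where it says the series, first, only, none or still open, it means among the compounds named here.

Measured in a functional assay on K562 cells (Homo sapiens) for antiproliferative activity, with a stated time of 72 h; on this read-out lower numbers stand for stronger inhibition and higher numbers for weaker inhibition:
- compound 1 `OC[C@H]1O[C@@H](n2cnc3c(NCc4ccccc4Cl)ncnc32)[C@H](O)[C@@H]1O`: 64000 nM
- compound 2 `OC[C@H]1O[C@@H](n2cnc3c(NCc4ccccc4Br)ncnc32)[C@H](O)[C@@H]1O`: 10000 nM
- compound 3 `COc1cccc(CNc2ncnc3c2ncn3[C@@H]2O[C@H](CO)[C@@H](O)[C@H]2O)c1OC`: > 166000 nM (a limit)

Compound 3 gives no number, only a limit: the limit of > 166000 nM in this assay, at which 1 of the 3 values shown sits.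

Compound 4 `OC[C@H]1O[C@@H](n2cnc3c(NCc4cccc(O)c4O)ncnc32)[C@H](O)[C@@H]1O` carries 2,3-dihydroxyphenyl in place of 2,3-dimethoxyphenyl on a saturated chain carbon bound to a nitrogen on an aromatic ring.

Going by the values given here, no measured step covers this exchange. The nearest are changes on the same aromatic group: an at least 2.5-fold higher number from compound 1 to compound 3 (0.41 log units; beyond the scatter), an at least 16-fold higher number from compound 2 to compound 3 (1.22 log units; beyond the scatter) and a 6.4-fold lower number from compound 1 to compound 2 (0.81 log units; beyond the scatter). All three lie beyond the scatter, so a real move is expected here too.

A modest to large move to a lower number is expected, estimated as an at least 5.5-fold lower number from compound 3 to compound 4 (0.74 log units; beyond the scatter) in this assay.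

For compound 4 the estimate is 30000 nM, with an expected range of 6000 nM to 150000 nM.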

Compound 4, half-maximal inhibitory concentration: 25800 nM
Estimate against measurement, compound 4: 1.2-fold (0.07 log units) above, and the stated range covers the measured number.
By their numbers in this assay, from the lowest: compound 2; then compound 4; then compound 1. At a limit, above all of these: compound 3.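

On the saturated chain carbon bound to a nitrogen on an aromatic ring, 2,3-dihydroxyphenyl in place of 2,3-dimethoxyphenyl gives a measurable number (an at least 6.4-fold lower number from compound 3 to compound 4 (0.80 log units; beyond the scatter)), so carrying two ring substituents does not by itself abolish activity in this series. Compound 4 sits between the two halogen compounds (a 2.6-fold higher number from compound 2 to compound 4 (0.41 log units; beyond the scatter); a 2.5-fold lower number from compound 1 to compound 4 (0.39 log units; beyond the scatter)). Compound 3 stands only at a limit, so the first step is a bound: the limit of > 166000 nM in this assay, at which 1 of the 4 values shown sits.

The compounds shown leave open whether a single hydroxyl on the phenyl ring would serve as well. From the compounds shown here alone, how an amine or a carboxylic acid there would read also remains open.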